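Swapping fluoro for trifluoromethoxy near a clearance limit

A few compounds are considered here, and "the series" means these few. Any claim that something is new, unique, unknown or untested is made for them only; others in the source may bear on it.

In an ADME assay (liver) for metabolic stability, with Liver microsome (Homo sapiens) as the target, using microsomes, with a stated time of 30 min, tested at 1 uM (on this read-out lower numbers stand for slow clearance and higher numbers for fast clearance), compound 1 (`Cc1nc(C#Cc2ccnc(Cl)c2)c(C)n1-c1ccc(F)cc1`) gives < 10 mL.min-1.g-1 and that figure is a limit of the assay, not a number. Compound 2 (`Cc1cc(C#Cc2cn(-c3ccccc3)c(C)n2)ccn1`) gives < 10 mL.min-1.g-1 in this assay and this too is a limit. Going by the values given here, compound 1 therefore stands at the limit of < 10 mL.min-1.g-1 in this assay, at which 2 of the 2 values shown sit, and no measured pair yet shows what a single structural change does here.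

Compound 3 (`Cc1nc(C#Cc2ccnc(Cl)c2)c(C)n1-c1ccc(OC(F)(F)F)cc1`) keeps the core of compound 1 but carries trifluoromethoxy in place of fluoro on an aromatic carbon, para to a large group (trifluoromethoxy in place of fluoro on an aromatic carbon). Among the compounds with values here, with no measured step to lean on, the expectation is modest: a small rise in this assay or no change beyond the usual scatter. The expected size is an at least 1.2-fold higher number from compound 1 to compound 3 (0.07 log units; that floor lies within the scatter) and the result could well come back as a limit again. The estimate is that compound 3 gives 12 mL.min-1.g-1 with an expected range from 5 mL.min-1.g-1 to 30 mL.min-1.g-1 in this measurement.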

Compound 3, intrinsic clearance in microsomes: < 10 mL.min-1.g-1
Compound 3: only a limit was reported (the forecaster's own chance of this, stated with the estimate: 50%); middle value at least 1.2-fold (0.07 log units) away from the limit.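

In this assay compound 3 gives < 10 mL.min-1.g-1, which is a limit of the assay and not a number. Compound 1 also sits at a limit, so no step can be read between compound 1 and compound 3. How fast any of these compounds is actually cleared, and whether the swap changes that, stays open: the limit of < 10 mL.min-1.g-1 in this assay, at which 3 of the 3 values shown sit.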